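This account rests on a few compounds, and the source may have more. Where it says the series, first, only, none or still open, it means among the compounds named here.

The compounds share a core and differ only in the groups at its edges. In a functional assay on SW480 cells (Homo sapiens) for cytotoxicity, read by MTT assay, with a stated time of 24 h (on this read-out higher numbers stand for weaker inhibition and lower numbers for stronger inhibition), compound 1, with the structure `C=CC1=C(C(=O)Nc2ccc(OCC)cc2)C(c2ccc(OC)cc2)OC1`, gives > 100000 nM, which is a limit of the assay rather than a measured number. Compound 2, with the structure `C=CC1=C(C(=O)NC(C)(C)C)C(c2ccc(F)cc2)OC1`, gives > 100000 nM, again a limit. Compound 3, with the structure `C=CC1=C(C(=O)Nc2ccc(OCC)cc2)C(c2ccc(F)cc2)OC1`, gives > 100000 nM, also a limit. Among the measured compounds shown here, the one change that can be traced between measured compounds, fluoro in place of methoxy on an aromatic carbon, is a step that the two limits leave unreadable from compound 1 to compound 3, so its size cannot be read. For the measured compounds named here, all the information gathered so far rests on (the limit of > 100000 nM in this assay, at which 3 of the 3 values shown sit), and no step of known size is available.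

Compound 4, with the structure `C=CC1=C(C(=O)Nc2ccc(C)cc2)C(c2ccc(OC)cc2)OC1`, differs from compound 1 by methyl in place of ethoxy on an aromatic carbon. Going by the values given here, no measured step bears directly on this change, and the values of compound 1 and compound 3 show only that two different groups at the related position both leave the activity past the limit. The expectation in this assay is therefore that compound 4 stays beyond the limit as well, with no step beyond the scatter. Compound 4 is expected to give about 200000 nM, in a range from 100000 nM to 1000000 nM. The expected step is a step that the limit leaves unreadable from compound 1 to compound 4.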

Compound 4, half-maximal inhibitory concentration: > 100000 nM
Compound 4 gave a limit, no number; the forecaster's own chance of this, stated with the estimate: 85%; the middle value is on the limit's open side.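

Compound 4 gives > 100000 nM, a limit and not a number, so no size can be read for the change from compound 1 to compound 4. The compounds shown leave open how far past the limit each one lies, and whether any group at the edges of the shared core would give a measurable value in this assay. The evidence comes down to one point: the limit of > 100000 nM in this assay, at which 4 of the 4 values shown sit.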